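Biphenylmethyl in place of bromobenzyl on a sulfonamide chain

This account rests on a few compounds, and the source may have more. Where it says the series, first, only, none or still open, it means among the compounds named here.

Three compounds share a core in which a bis(trifluoromethyl)phenyl sulfonamide is joined through a three-carbon chain to a secondary amine carrying a benzylic group. Compound 1 `CC(C)(C)c1ccc(CNCCCNS(=O)(=O)c2cc(C(F)(F)F)cc(C(F)(F)F)c2)cc1` carries a 4-(tert-butyl)phenyl group there, compound 2 `COc1ccc(CNCCCNS(=O)(=O)c2cc(C(F)(F)F)cc(C(F)(F)F)c2)cc1OC` a 3,4-dimethoxyphenyl group, and compound 3 `O=S(=O)(NCCCNCc1ccc(Br)cc1)c1cc(C(F)(F)F)cc(C(F)(F)F)c1` a 4-bromophenyl group. In a functional assay on DU-145 cells (Homo sapiens) for inhibition, read by MTT assay, with a stated time of 72 h (on this read-out higher numbers stand for weaker inhibition of growth and lower numbers for stronger inhibition of growth), compound 1 gives 2700 nM, compound 2 gives 4000 nM, and compound 3 gives 2600 nM. All three sit together: the step of a 1.0-fold lower number from compound 1 to compound 3 (0.02 log units; within the scatter) and the step of a 1.5-fold lower number from compound 2 to compound 3 (0.19 log units; within the scatter) are both within the scatter, as is a 1.5-fold higher number from compound 1 to compound 2 (0.17 log units; within the scatter), so compound 3 is not set apart from the other two.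

Compound 4 `O=S(=O)(NCCCNCc1ccc(-c2ccccc2)cc1)c1cc(C(F)(F)F)cc(C(F)(F)F)c1` differs from compound 3 by a single change: phenyl in place of bromo on an aromatic carbon. Among the compounds with values here, none of the measured steps involves a phenyl group at this position, so the expectation rests on the observation that swapping bromo for tert-butyl or for dimethoxyphenyl in this place moved this assay by no more than the scatter. On that basis the expected step of no change at the digits printed from compound 3 to compound 4 (within the scatter) is none beyond the scatter. Compound 4 is therefore estimated at 2600 nM, with a range from 1000 nM to 7000 nM.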

Compound 4, concentration for 50% growth inhibition: 2700 nM
For compound 4 the middle estimate is 1.0-fold (0.02 log units) below the measured one; the range from low to high includes it.
By their numbers in this assay, from the lowest: compounds 3, 1, 4 and 2 (each within the scatter of the next).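

In this assay the swap of bromo for phenyl gives a 1.0-fold higher number from compound 3 to compound 4 (0.02 log units; within the scatter) and the swap of tert-butyl for phenyl gives no change at the digits printed from compound 1 to compound 4 (within the scatter) and both steps stay within the usual scatter. The earlier compounds shown here varied this benzylic group only through small substituents on its ring, whereas here one bromine atom gives way to a phenyl of 6 heavy atoms, which adds a whole six-membered aromatic ring on an aromatic carbon, para to a large group, and the growth-inhibition number still does not separate from the others. So a second aromatic ring at this place can be added with no measurable effect on the read-out, although nothing available here says why that is so.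

What remains open is whether this flat picture holds for groups of another kind at the same place, such as an amine or a carboxylic acid, since every substituent shown lacks both. The compounds also leave open how a longer chain between the sulfonamide and the secondary amine would affect growth inhibition, since all of them share the same chain.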